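Nitro to Hydroxy Swap on Two Chromone Cores

This account rests on a few compounds, and the source may have more. Where it says the series, first, only, none or still open, it means among the compounds named here.

Measured so far:
compound 1 `COC(=O)c1c(-c2ccc([N+](=O)[O-])cc2)oc2cc(OC)ccc2c1=O`, 1.12 ug/mL
compound 2 `COC(=O)c1c(-c2ccc(O)cc2)oc2cc(OC)ccc2c1=O`, 20.1 ug/mL
compound 3 `COc1ccc2oc(-c3ccc([N+](=O)[O-])cc3)c(C(=O)O)c(=O)c2c1`, a limit only

In a functional assay on Malme-3M cells (Homo sapiens) for cytotoxicity, read by MTT assay, with a stated time of 6 days (on this read-out higher numbers stand for an effect only at larger amounts of compound and lower numbers for an effect already at smaller amounts), compound 1 gives 1.12 ug/mL. The change hydroxy in place of nitro on an aromatic carbon gives an 18-fold higher number from compound 1 to compound 2 (1.25 log units; beyond the scatter). Compound 3 belongs to a different core; the difference between the two cores is not broken down here. For compound 3 this assay reports only a limit, > 25 ug/mL, one of the values described by the limit of > 25 ug/mL in this assay, at which 1 of the 3 values shown sits.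

Compound 4 `COc1ccc2oc(-c3ccc(O)cc3)c(C(=O)O)c(=O)c2c1` is not yet measured. Its relation to compound 3 is the same change, (hydroxy in place of nitro on an aromatic carbon), with the same place. Because compound 1 to compound 2 showed an 18-fold higher number from compound 1 to compound 2 (1.25 log units; beyond the scatter), the step from compound 3 to compound 4 is expected to be a step that the limit leaves unreadable from compound 3 to compound 4 or to remain a limit. Compound 4 is therefore estimated at 100 ug/mL, between 25 ug/mL and 500 ug/mL.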

Compound 4, concentration for half-maximal effect: > 25 ug/mL
Compound 4: only a limit was reported; the forecaster's own chance of this, stated with the estimate: 85%; the middle value is on the limit's open side.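

In this assay, within the data shown here, compound 3 and compound 4 each give only a limit, so no step between them can be read: the limit of > 25 ug/mL in this assay, at which 2 of the 4 values shown sit. As far as these compounds go, whether hydroxy in place of nitro changes the number on this core, as it does from compound 1 to compound 2, stays open.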